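A tert-Butylphenoxy Analogue Approaches the Solubility Assay

This account rests on a few compounds, and the source may have more. Where it says the series, first, only, none or still open, it means among the compounds named here.

Compound 3 `COc1cccc(CNCCCNc2ccnc3cc(Oc4cccc(N(C)C)c4)ccc23)c1O` is measured in a physicochemical assay for solubility, with a stated time of 18 h, at pH 7.4 (on this read-out lower numbers stand for lower solubility and higher numbers for higher solubility), where compound 3 gives 14500 nM. Compound 1 `COc1cccc(CNCCCNc2ccnc3cc(Oc4ccc(F)cc4)ccc23)c1O` gives 14500 nM in this assay, and the two stand level, together the highest of the three numbers, with no change at the digits printed from compound 1 to compound 3 (within the scatter). Compound 2 `COc1cccc(CNCCCNc2ccnc3cc(Cc4ccc(F)cc4)ccc23)c1O` gives 4200 nM in this assay; the steps of a 3.5-fold lower number from compound 1 to compound 2 (0.54 log units; beyond the scatter) and a 3.5-fold higher number from compound 2 to compound 3 (0.54 log units; beyond the scatter) are the only ones beyond the scatter. Compound 4 `COc1cccc(CNCCCNc2ccnc3cc(Oc4ccc(C(C)(C)C)cc4)ccc23)c1O` differs from compound 3 by 4-(tert-butyl)phenyl in place of 3-(dimethylamino)phenyl on an oxygen on an aromatic ring. Going by the values given here, no measured step replaces the group on the oxygen on an aromatic ring with 4-(tert-butyl)phenyl, so the expectation leans on the size seen in a 3.5-fold lower number from compound 1 to compound 2 (0.54 log units; beyond the scatter). A modest fall in solubility is expected, a 3.2-fold lower number from compound 3 to compound 4 (0.51 log units; beyond the scatter). Compound 4 is therefore estimated at 4500 nM, within a range from 1500 nM to 13000 nM.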

Compound 4, solubility: 14500 nM
Compound 4: middle estimate off by 3.2-fold (0.51 log units), on the low side, outside the stated range (above it).
By their numbers in this assay, from the lowest: compound 2; then compounds 1, 3 and 4 (each within the scatter of the next).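

With 4-(tert-butyl)phenyl on the oxygen, the entering group carries no nitrogen, yet the solubility assay read-out holds level (no change at the digits printed from compound 3 to compound 4 (within the scatter)). In this assay, going by these compounds alone, tert-butyl in place of fluoro on an aromatic carbon likewise leaves the number level (no change at the digits printed from compound 1 to compound 4 (within the scatter)). 4-(tert-butyl)phenoxy in place of 4-fluorobenzyl gives a step beyond the scatter (a 3.5-fold higher number from compound 2 to compound 4 (0.54 log units; beyond the scatter)), so compound 2 remains the only compound set apart. On these data alone, whether a carboxylic acid or a morpholine on this phenyl ring would also hold this level stays open. No measurement shown accounts for the level numbers.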